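A Benzyl Swap in a Flat Aryl Series

This account rests on a few compounds, and the source may have more. Where it says the series, first, only, none or still open, it means among the compounds named here.

In a functional assay on MGC-803 cells (Homo sapiens) for inhibition, read by sulforhodamine B assay (a lower number here means a stronger inhibitor, a higher number a weaker inhibitor), compound 1 (`O=C1C(Nc2ccc(I)cc2)=CC(=O)c2c1nc1n2[C@H]2OC[C@@H](O)[C@H]2OC1`) gives 2150 nM, compound 2 (`O=C1C(Nc2ccc(Br)cc2)=CC(=O)c2c1nc1n2[C@H]2OC[C@@H](O)[C@H]2OC1`) gives 2020 nM and compound 3 (`COc1ccc(NC2=CC(=O)c3c(nc4n3[C@H]3OC[C@@H](O)[C@H]3OC4)C2=O)cc1`) gives 2150 nM. Compound 3 thus stands level with compound 1, and all three numbers lie within the scatter of each other.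

The unmeasured compound 4 (`O=C1C(NCc2ccccc2)=CC(=O)c2c1nc1n2[C@H]2OC[C@@H](O)[C@H]2OC1`) carries benzyl in place of 4-methoxyphenyl on an amine nitrogen. The measured steps that bear on this only exchange the group on an aromatic carbon: a 1.1-fold lower number from compound 1 to compound 2 (0.03 log units; within the scatter), no change at the digits printed from compound 1 to compound 3 (within the scatter) and a 1.1-fold higher number from compound 2 to compound 3 (0.03 log units; within the scatter). Each lies within the scatter. None of them puts benzyl on the amine nitrogen, so the data offer no direct measure of this change, and the expectation is correspondingly uncertain.

Starting from compound 3 at 2150 nM, no shift beyond the scatter is expected in this assay, in either direction. The estimated step is a 1.2-fold higher number from compound 3 to compound 4 (0.07 log units; within the scatter). For compound 4 the expected value is 2500 nM, with an estimated range from 1000 nM to 6500 nM.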

Compound 4, half-maximal inhibitory concentration: 3490 nM
Compound 4: the middle estimate sits 1.4-fold (0.14 log units) below what was measured; the measured number falls inside the stated range.
By their numbers in this assay, from the lowest: compounds 2, 1, 3 and 4 (each within the scatter of the next).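

In this assay the step of a 1.6-fold higher number from compound 3 to compound 4 (0.21 log units; within the scatter) is joined by the steps of a 1.7-fold higher number from compound 2 to compound 4 (0.24 log units; within the scatter) and a 1.6-fold higher number from compound 1 to compound 4 (0.21 log units; within the scatter) and all three lie within the scatter. The earlier compounds shown here exchanged only the group on an aromatic carbon, whereas these steps replace the whole group on the amine nitrogen, and for these four compounds the change from (4-methoxyphenyl)amino to benzylamino gives no difference that can be told from the scatter. Nothing among the data shown accounts for this result.

Open, from the compounds shown here alone, is how a phenethyl group, with its longer chain, or a cyclohexyl group, with no aromatic ring, would read on the same amine nitrogen. Also open, going by these compounds, is whether a methoxy, bromo or iodo group on the benzyl ring would leave the number within the scatter.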